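Dithiocarbamate chromones: piperidinyl in place of methyl(phenyl)amino

This account rests on a few compounds, and the source may have more. Where it says the series, first, only, none or still open, it means among the compounds named here.

Measured so far in a functional assay on SW480 cells (Homo sapiens) for antiproliferative activity, read by MTT assay, with a stated time of 72 h; on this read-out higher numbers stand for weaker inhibition and lower numbers for stronger inhibition:
compound 1 `CCOC(=O)c1cc(=O)c2cc(CSC(=S)N(C)c3ccccc3)ccc2o1` — > 25000 nM
compound 2 `O=c1c(Cl)c(CSC(=S)N2CCCCC2)oc2ccccc12` — 690 nM
compound 3 `O=c1c(CSC(=S)N2CCOCC2)coc2ccccc12` — 5900 nM

Compound 1 sits at a limit of this assay, (the limit of > 25000 nM in this assay, at which 1 of the 3 values shown sits), so no number is known for it. Within the data shown here, compound 2 and compound 3 give numbers, and no step between any two of the measured compounds is available. Compound 4 `CCOC(=O)c1cc(=O)c2cc(CSC(=S)N3CCCCC3)ccc2o1` keeps the core of compound 1 and carries piperidin-1-yl in place of methyl(phenyl)amino on a thiocarbonyl carbon. Among the measured compounds shown here, no measured pair shows this change on this core; the expected direction is towards stronger inhibition, since compound 2 with the piperidin-1-yl group gives 690 nM, but the size of the step cannot be read off. Compound 4 is estimated at 8000 nM (range 2000 nM to 30000 nM), which would mean an expected step of an at least 3.1-fold lower number from compound 1 to compound 4 (0.49 log units; beyond the scatter).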

Compound 4, half-maximal inhibitory concentration: > 25000 nM
Compound 4 gave a limit, no number (the forecaster's own chance of this, stated with the estimate: 35%); at least 3.1-fold (0.49 log units) between middle value and limit.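

Compound 1 and compound 4 both sit at a limit and give no number, so no step between them can be read: the limit of > 25000 nM in this assay, at which 2 of the 4 values shown sit.

As far as these compounds go, whether piperidin-1-yl in place of methyl(phenyl)amino on a thiocarbonyl carbon changes inhibition on the core of compound 1 stays open.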